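Vinyl sulfonate esters as Nrf2 activators: chloro position

The source may hold more compounds than are shown below. What is called first, only, known or untested is meant among the compounds shown, and "the series" means these compounds.

Compound 1 `COc1ccc(NS(=O)(=O)/C=C/c2ccccc2Cl)cc1` and compound 2 `COc1ccccc1OS(=O)(=O)/C=C/c1ccccc1Cl` share the chlorostyryl sulfonyl group but differ in the aryl partner, an anilide in compound 1 and an aryl ester in compound 2. In an assay on U2OS cells for activation of nuclear factor erythroid 2-related factor 2 (Homo sapiens), read by chemiluminescence, with a stated time of 6 h (on this read-out lower numbers stand for an effect already at smaller amounts and higher numbers for an effect only at larger amounts of compound), compound 1 gives only a limit, > 10000 nM, and no number. In this assay, within the data shown here, compound 2 gives 76 nM, the only number in the set so far, so compound 2 is the sole point of reference for the ester sub-series. Compound 1 sits at the limit of > 10000 nM in this assay, at which 1 of the 2 values shown sits.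

Compound 3 `COc1ccccc1OS(=O)(=O)/C=C/c1cccc(Cl)c1` keeps the ester of compound 2 and changes only the styryl aryl: 3-chlorophenyl in place of 2-chlorophenyl on a double-bonded chain carbon bound to a double-bonded chain carbon. Among the measured compounds shown here, no measured pair shows what such a shift of the chlorine does here, so the direction cannot be read from the set. The step from compound 2 to compound 3 is expected to be small, around a 2.0-fold higher number from compound 2 to compound 3 (0.30 log units; within the scatter), possibly a slight loss but not clearly beyond the scatter. In this assay compound 3 is therefore estimated at 150 nM, within a range from 40 nM to 600 nM.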

Compound 3, half-maximal effective concentration: 698 nM
Estimate against measurement, compound 3: 4.7-fold (0.67 log units) below; the measured number lies above the stated range.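

In this assay the place of the chlorine on the styryl aryl turns out to matter: 3-chlorophenyl in place of 2-chlorophenyl on a double-bonded chain carbon bound to a double-bonded chain carbon gives a 9.2-fold higher number from compound 2 to compound 3 (0.96 log units; beyond the scatter), although the two compounds have the same atoms, joined differently. Among these compounds, this is the first measured step within the ester sub-series, and it lies beyond the scatter, so of this pair compound 2 keeps the lower number and remains the reference for further comparison. Nothing measured here bears on the reason for this step.

Going by these compounds, what a nitrile, an amine or a carboxylic acid in place of the chlorine would do remains open, as does whether the styryl aryl needs any substituent at all for an effect at low amounts of compound. Compound 1 differs from compound 2 and from compound 3 in more than one place, so the contribution of the anilide relative to the aryl ester cannot be read from the compounds shown, and the same holds for any effect of moving the chlorine in the anilide.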